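The source may hold more compounds than are shown below. What is called first, only, known or untested is meant among the compounds shown, and "the series" means these compounds.

Three compounds with a nitro group on a fused core have been measured in a physicochemical assay for solubility, read by HPLC, measured as kinetic solubility; a lower number here means a less soluble compound, a higher number a more soluble compound. Compound 1 `CC1(COCc2ccc(OCc3ccccc3)cc2)Cn2cc([N+](=O)[O-])nc2S1` gives 1.2 ug/mL, the lowest of the three numbers. Compound 2 `CN1CC(OCc2ccc(OCc3ccccc3)cc2)Cn2nc([N+](=O)[O-])cc21` gives 2.4 ug/mL, a number that lies within the scatter of repeated measurements of compound 1, so the two cannot be told apart. Compound 3 `O=[N+]([O-])c1cn2c(n1)[S+]([O-])CC(OCc1ccc(OC(F)(F)F)cc1)C2` gives 39 ug/mL, which stands well beyond the scatter above compound 1.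

Compound 4 `O=[N+]([O-])c1cn2c(n1)SC(COCc1ccc(OCc3ccccc3)cc1)C2` has not yet been measured. It differs from compound 1 in one place: hydrogen in place of methyl on a saturated ring carbon. Going by the values given here, no pair of measured compounds shows what this change alone does in this assay, so the expectation rests on the values at hand. A change of one carbon and no ring is small, and the step from compound 1 to compound 4 is expected to be modest, most likely upward but possibly no larger than the scatter: a 1.8-fold higher number from compound 1 to compound 4 (0.26 log units; within the scatter). Compound 4 is therefore estimated at 2.2 ug/mL in this assay, with a likely range from 0.8 ug/mL to 6 ug/mL.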

Compound 4, solubility: 1.2 ug/mL
The estimate for compound 4 lay 1.8-fold (0.26 log units) above the measured number; the range from low to high includes it.
By their numbers in this assay, from the lowest: compounds 1, 4 and 2 (each within the scatter of the next); then compound 3.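

In this assay, going by these compounds alone, hydrogen in place of methyl on a saturated ring carbon gives no change at the digits printed from compound 1 to compound 4 (within the scatter), and this is the first pair here that differs in only one place. At this carbon, next to the ring sulfur, the methyl can therefore be exchanged for hydrogen with no change that can be told from the scatter, and both compounds remain far from the number of compound 3 . Nothing available explains why this exchange leaves the number where it is.

On these data alone, this is a single exchange on a single background, so it remains open whether hydrogen in place of methyl would behave the same way on other cores. Also open, as far as these compounds go, is whether a longer chain, an amine or a carboxylic acid on this carbon would give a number beyond the scatter.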